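Hydrazone aryl variation on the shared core

This account rests on a few compounds, and the source may have more. Where it says the series, first, only, none or still open, it means among the compounds named here.

Measured so far in an assay on CHO-K1 cells for displacement of a labelled ligand from adenosine receptor A1 (Homo sapiens), read by scintillation counting, with a stated time of 60 min; on this read-out higher numbers stand for weaker inhibition and lower numbers for stronger inhibition:
compound 1, `N#Cc1ccc(/C=N/Nc2nc(N)c3ncn([C@@H]4O[C@H](CO)[C@@H](O)[C@H]4O)c3n2)cc1`: 4.1 nM
compound 2, `COc1cc(/C=N/Nc2nc(N)c3ncn([C@@H]4O[C@H](CO)[C@@H](O)[C@H]4O)c3n2)ccc1OCc1ccccc1`: 9140 nM

Compound 1 holds the lowest number of the two in this assay; compound 2 sits far above it, well beyond the scatter. Going by the values given here, no step between two measured compounds differing in one place is available. Compound 3, `Nc1nc(N/N=C/c2ccc3ncccc3c2)nc2c1ncn2[C@@H]1O[C@H](CO)[C@@H](O)[C@H]1O`, differs from compound 1 by quinolin-6-yl in place of 4-cyanophenyl on a carbon with a double bond to nitrogen. Among the compounds with values here, with no comparable step to lean on, a modest loss, possibly within the scatter, is expected for a 3.7-fold higher number from compound 1 to compound 3 (0.56 log units; beyond the scatter). Compound 3 is therefore expected to give about 15 nM, with a range from 3 nM to 80 nM.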

Compound 3, inhibition constant: 9.8 nM
Compound 3: middle estimate off by 1.5-fold (0.18 log units), on the high side; low and high end bracket the measured number.
By their numbers in this assay, from the lowest: compound 1; then compound 3; then compound 2.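

The step of a 2.4-fold higher number from compound 1 to compound 3 (0.38 log units; beyond the scatter) in this assay is modest and shows that this position tolerates a change of aryl group: with quinolin-6-yl, which carries no nitrile, compound 3 keeps a low number of 9.8 nM on the shared core. The nitrile of compound 1 is therefore not required for a low number here. No measurement on hand bears on why the step has this size.

Open, on these data alone, is whether the ring nitrogen of quinolin-6-yl matters, which a naphthalen-2-yl group would address. Also open, as far as these compounds go, is how an amine or a carboxylic acid in place of the nitrile would read.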